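Bromo for Chloro on Two Related Cores

A few compounds are considered here, and "the series" means these few. Any claim that something is new, unique, unknown or untested is made for them only; others in the source may bear on it.

The measured compounds and their values in a functional assay on A549 cells (Homo sapiens) for antiproliferative activity, read by MTT assay, with a stated time of 72 h; a higher number here means a weaker inhibitor, a lower number a stronger inhibitor:
compound 1 `O=C(Nc1ccc(Oc2ccnc3[nH]ccc23)c(F)c1)c1cc2cccnc2n(-c2ccc(Cl)cc2)c1=O` gives 110 nM
compound 2 `O=C(Nc1ccc(Oc2ccnc3[nH]ccc23)c(F)c1)c1cc2cccnc2n(-c2ccc(Br)cc2)c1=O` gives 210 nM
compound 3 `Cn1ccc2c(Oc3ccc(NC(=O)c4cc5cccnc5n(-c5ccc(Cl)cc5)c4=O)cc3)ccnc21` gives 630 nM

Compound 1 and compound 2 share one core. Compound 3 carries a different core; the difference between the two cores is not broken down here. Within the first core, the change from compound 1 to compound 2 is bromo in place of chloro on an aromatic carbon, and it made a step of a 1.9-fold higher number from compound 1 to compound 2 (0.28 log units; within the scatter). Compound 3 gives the highest number of the three, and the values of compound 2 and compound 3 in this assay lie apart from each other beyond the scatter.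

Compound 4 `Cn1ccc2c(Oc3ccc(NC(=O)c4cc5cccnc5n(-c5ccc(Br)cc5)c4=O)cc3)ccnc21` is compound 3 carrying the same kind of change, (bromo in place of chloro on an aromatic carbon); the place in both cases is on an aromatic carbon of a six-membered aromatic ring of carbon only, para to a large group, so it is the same change. Because the step of a 1.9-fold higher number from compound 1 to compound 2 (0.28 log units; within the scatter) stayed within the scatter, compound 4 is expected to show a step of a 1.5-fold higher number from compound 3 to compound 4 (0.18 log units; within the scatter) in this assay. The estimate for compound 4 is 950 nM, with a range from 400 nM to 2500 nM.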

Compound 4, half-maximal inhibitory concentration: 680 nM
For compound 4 the middle estimate is 1.4-fold (0.15 log units) above the measured one; low and high end bracket the measured number.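

In this assay, bromo in place of chloro on the second core gave a 1.1-fold higher number from compound 3 to compound 4 (0.03 log units; within the scatter). Set beside the earlier step on the first core, the change carried from one core to the other with no difference that can be told apart from the scatter: the same change on two cores in this assay, a 1.9-fold higher number (0.28 log units; within the scatter) from compound 1 to compound 2 and a 1.1-fold higher number (0.03 log units; within the scatter) from compound 3 to compound 4, 1.8-fold (0.25 log units) apart, within the scatter of two such steps This shows only that, on these two cores and in this single assay, going from 4-chlorophenyl to 4-bromophenyl made no step beyond the scatter; it does not show that the change would behave the same way on any other core, and two pairs set no general rule.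

The compounds shown leave open whether another group at this place on the aromatic ring, such as a methoxy group, an amine or a carboxylic acid, would also carry across the two cores with steps that match. They also leave open whether a smaller halogen, fluoro, would behave as bromo and chloro do here.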